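Trimming the benzyl arm of a coumarin propargylamine

The source may report more compounds than this note shows. Statements on the series, on what has been measured and on what is new or still open speak of the compounds shown alone.

Measured compounds:
compound 1 `C#CCN(CCCCOc1ccc2ccc(=O)oc2c1)Cc1ccc(OC)cc1`: 1130 nM
compound 2 `C#CCN(CCCOc1ccc2ccc(=O)oc2c1)Cc1ccc(OC)cc1`: 6080 nM
compound 3 `C#CCN(CCCCOc1ccc2ccc(=O)oc2c1)Cc1cccc(F)c1`: 1550 nM

In an assay on isolated protein for inhibition of Amine oxidase [flavin-containing] B (Homo sapiens), read by fluorescence and Amplex Red, with stated times of 15 min and 20 min (a higher number here means a weaker inhibitor, a lower number a stronger inhibitor), compound 1 gives the lowest of the three numbers; compound 3 sits within the scatter of it, a 1.4-fold higher number from compound 1 to compound 3 (0.14 log units; within the scatter), while compound 2, which carries a shorter linker, shows a number beyond the scatter. Compound 4 `C#CCN(C)CCCCOc1ccc2ccc(=O)oc2c1` differs from compound 1 by hydrogen in place of 4-methoxyphenyl on a saturated chain carbon bound to an amine nitrogen. Within the data shown here, no measured step covers the loss of the whole ring; the only neighbouring step, a 1.4-fold higher number from compound 1 to compound 3 (0.14 log units; within the scatter), shows that exchanging one ring for another barely moves the number. Removing the ring altogether is a larger change, so a moderate rise in this assay is expected for compound 4, about a 2.2-fold higher number from compound 1 to compound 4 (0.34 log units; beyond the scatter). The estimate for compound 4 is 2500 nM, within 600 nM to 10000 nM.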

Compound 4, half-maximal inhibitory concentration: 27 nM
Compound 4: middle estimate off by 93-fold (1.97 log units), on the high side; measured number below the stated range.
By their numbers in this assay, from the lowest: compound 4; then compounds 1 and 3 (each within the scatter of the next); then compound 2.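

Within this assay, the earlier swap of one ring for another hardly moved the number, but removing the ring from this carbon changes it greatly, leaving methyl on the nitrogen (a 42-fold lower number from compound 1 to compound 4 (1.62 log units; beyond the scatter)). The same holds starting from the 3-fluorophenyl ring (a 57-fold lower number from compound 3 to compound 4 (1.76 log units; beyond the scatter)). Nothing available explains this difference. The compounds shown leave open how much larger than methyl this group can grow before the number rises. An ethyl group on the nitrogen, with the rest of compound 4 unchanged, would begin to test that.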